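Swapping a sulfonamide arm for chlorine on the shared core

The source may hold more compounds than are shown below. What is called first, only, known or untested is meant among the compounds shown, and "the series" means these compounds.

Compound 1 `Cn1nc2c(=O)n(CC3(O)CCN(Cc4ccc(-c5ccco5)cc4Cl)CC3)cnc2c1-c1ccc(CNS(C)(=O)=O)cc1` is the strongest of the three measured compounds in an assay on isolated protein for inhibition of ubiquitin carboxyl-terminal hydrolase 7 (Homo sapiens), with stated times of 30 min and 2 h (a lower number here means a stronger inhibitor, a higher number a weaker inhibitor), where compound 1 gives 65.3 nM. Compound 2 `Cn1nc2c(=O)n(CC3(O)CCN(Cc4ccc(-c5n[nH]c(=O)o5)cc4Cl)CC3)cnc2c1-c1ccc(CN)cc1` gives 171 nM in this assay, and compound 3 `Cn1nc2c(=O)n(CC3(O)CCN(Cc4ccc(-c5ccc(C(=O)O)o5)cc4Cl)CC3)cnc2c1-c1ccc(CN)cc1` gives 753 nM. For the measured compounds named here, the one step measured between neighbouring structures, a 4.4-fold higher number from compound 2 to compound 3 (0.64 log units; beyond the scatter), sits on the far aryl end of the molecule and shows that a change there shifts the number modestly.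

Compound 4 `Cn1nc2c(=O)n(CC3(O)CCN(Cc4ccc(-c5ccco5)cc4Cl)CC3)cnc2c1-c1ccc(Cl)cc1` is the compound still to be tested. It differs from compound 1 in one place: chloro in place of (methanesulfonamido)methyl on an aromatic carbon. Going by the values given here, no measured step bears directly on this change, since compounds 2 and 3 carry an aminomethyl group at that position rather than either of the two groups involved here, and the step from compound 2 to compound 3 concerns a different part of the structure. What the data do show is that compound 1 holds the lowest number with both its sulfonamide arm and its furan ring present, and that every variation from it so far has given a higher number. Taking a group with one hydrogen-bond donor and two acceptors away and leaving a single chlorine is therefore expected to weaken inhibition by a 3.1-fold higher number from compound 1 to compound 4 (0.49 log units; beyond the scatter), and compound 4 is estimated to give 200 nM in this assay, within a range from 50 nM to 800 nM.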

Compound 4, half-maximal inhibitory concentration: 143 nM
Beside the measured number, compound 4's estimate is 1.4-fold (0.15 log units) above it; measured number inside the range.
By their numbers in this assay, from the lowest: compound 1; then compounds 4 and 2 (each within the scatter of the next); then compound 3.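

In this assay, the first single change measured at this position, chloro in place of (methanesulfonamido)methyl, gives a 2.2-fold higher number from compound 1 to compound 4 (0.34 log units; beyond the scatter). The step is beyond the scatter but modest: a group of 6 heavy atoms with a hydrogen-bond donor and acceptors contributes to the lower number of compound 1, yet compound 4 remains an inhibitor in this assay with only a single chlorine on that aromatic carbon, so the full arm is not needed for measurable inhibition. Nothing among the data shown accounts for the size of this step, so the structural basis of the shift remains unknown.

The compounds shown leave open which part of the arm matters, since a plain methyl, a methoxy group or a bare hydrogen on the same carbon would separate the effect of the chain from that of the sulfonamide. They also leave open how aminomethyl compares at this position. Compound 2 and compound 3 carry that group but differ from compound 1 at the far aryl end as well, and a furan-bearing aminomethyl analogue would be needed for a comparison in one place.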